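Amino Group Enters Where Trifluoromethyl Sat Before

The source may report more compounds than this note shows. Statements on the series, on what has been measured and on what is new or still open speak of the compounds shown alone.

Of the compounds shown here, three sharing one core have been measured in an assay on membranes from spleen (Cavia porcellus) for binding affinity to leukotriene B4 receptor 1 (Homo sapiens); on this read-out higher numbers stand for weaker inhibition and lower numbers for stronger inhibition. Compound 1 `O=C(O)CCCCCOc1cc(-c2ccccc2)c2ccccc2n1` gives 700 nM. Compound 2 `CC(C)(CCCCOc1cc(-c2ccccc2)c2ccccc2n1)C(=O)O` gives 183 nM, and compound 3 `CC(C)(CCCCOc1cc(-c2ccc(C(F)(F)F)cc2)c2ccccc2n1)C(=O)O` gives 300 nM. Compound 2 thus carries the lowest number of the three: a 3.8-fold lower number from compound 1 to compound 2 (0.58 log units; beyond the scatter) lies beyond the scatter, whereas a 1.6-fold higher number from compound 2 to compound 3 (0.21 log units; within the scatter) stays within it, so compound 2 and compound 3 cannot be told apart on these numbers.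

Compound 4 `CC(C)(CCCCOc1cc(-c2ccc(N)cc2)c2ccccc2n1)C(=O)O` has not yet been measured. It differs from compound 2 by amino in place of hydrogen on an aromatic carbon, on an aromatic carbon of a six-membered aromatic ring of carbon only, para to a large group; cut one bond further out, the difference reads phenyl to 4-aminophenyl. For the measured compounds named here, only one measured step touches that same place, the one in which trifluoromethyl entered in place of hydrogen: a 1.6-fold higher number from compound 2 to compound 3 (0.21 log units; within the scatter). That step was small, so in this assay a step of similar size, with no firm direction, is expected here, the estimated step being a 1.4-fold higher number from compound 2 to compound 4 (0.14 log units; within the scatter). The expected value for compound 4 is therefore 250 nM, most likely falling between 100 nM and 650 nM.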

Compound 4, half-maximal inhibitory concentration: 40 nM
Compound 4: middle estimate off by 6.3-fold (0.80 log units), on the high side, outside the stated range (below it).
By their numbers in this assay, from the lowest: compound 4; then compounds 2 and 3 (each within the scatter of the next); then compound 1.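

This aromatic carbon, para to a large group, proved able to move the number in this assay: amino in place of hydrogen gives a 4.6-fold lower number from compound 2 to compound 4 (0.66 log units; beyond the scatter) where trifluoromethyl had given only a 1.6-fold higher number from compound 2 to compound 3 (0.21 log units; within the scatter) at the same place. Exchanging one of these groups directly for the other gives a 7.5-fold lower number from compound 3 to compound 4 (0.88 log units; beyond the scatter) and so separates them clearly, which means the small earlier step did not show that this place is insensitive to change, only that trifluoromethyl and hydrogen could not be told apart there. What lies behind the lower number for amino cannot be said, as no measurement bearing on the cause is available.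

The compounds shown leave open whether the lower number belongs to the amino group in particular or would also appear with a hydroxyl, a methylamino, a dimethylamino or an acetamide group at this place. They also leave open whether amino would give a step of similar size on the unbranched chain of compound 1, or at another carbon of the same ring.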